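From an open butylamine to a pyrrolidine ring

The source may report more compounds than this note shows. Statements on the series, on what has been measured and on what is new or still open speak of the compounds shown alone.

Measured compounds, with their results in a functional assay on the whole organism for inhibition of sodium-dependent dopamine transporter (Mus musculus); on this read-out lower numbers stand for an effect already at smaller amounts and higher numbers for an effect only at larger amounts of compound:
- compound 1 `CCOC(=O)Nc1cccc2c1CN(C)CC2c1ccccc1` gives 2.5 mg/kg
- compound 2 `CN1Cc2c(NC(=O)OCc3ccccc3)cccc2C(c2ccccc2)C1` gives 25 mg/kg
- compound 3 `CCCCNCC(=O)Nc1cccc2c1CN(C)CC2c1ccccc1` gives 25 mg/kg

Compound 3 stands level with compound 2 at the digits shown, the two sharing the highest number of the three, and it is furthest from compound 1, as a 10-fold higher number from compound 1 to compound 3 (1.00 log units; beyond the scatter). Against compound 2 the comparison reads no change at the digits printed from compound 2 to compound 3 (within the scatter).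

Compound 4 `CN1Cc2c(NC(=O)CN3CCCC3)cccc2C(c2ccccc2)C1` keeps the shared core of compound 3 and changes only the amine on the side chain: pyrrolidin-1-yl in place of butylamino on a saturated chain carbon bound to a carbonyl carbon.

For the measured compounds named here, no measured step swaps one amine for another at this place. The two steps that touch this carbonyl substituent, a 10-fold higher number from compound 1 to compound 3 (1.00 log units; beyond the scatter) and no change at the digits printed from compound 2 to compound 3 (within the scatter), show that a large exchange there can leave this assay unmoved or shift it modestly. With the same atom count kept and only a ring closed, no change beyond the scatter is expected, no change at the digits printed from compound 3 to compound 4 (within the scatter). Compound 4 is therefore estimated at 25 mg/kg, within 8 mg/kg to 80 mg/kg.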

Compound 4, dose for half-maximal effect: 45 mg/kg
Estimate against measurement, compound 4: 1.8-fold (0.26 log units) below; the measured number falls inside the stated range.
By their numbers in this assay, from the lowest: compound 1; then compounds 2, 3 and 4 (each within the scatter of the next).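

In this assay, for the compounds shown here, the step from the open butylamino group to the pyrrolidin-1-yl ring on the saturated chain carbon bound to a carbonyl carbon is a 1.8-fold higher number from compound 3 to compound 4 (0.26 log units; within the scatter), the first amine-for-amine exchange at this place. Closing the ring and giving up the hydrogen-bond donor of butylamino therefore brings no change that can be told from scatter. The step of a 1.8-fold higher number from compound 2 to compound 4 (0.26 log units; within the scatter) is also within the scatter, whereas an 18-fold higher number from compound 1 to compound 4 (1.26 log units; beyond the scatter) lies beyond it, so among these compounds only the ethoxy group of compound 1 stands apart on the carbonyl carbon.

No other measurement is available to explain these numbers. From the compounds shown here alone, it remains open whether a piperidine, a morpholine or a dimethylamino group on the same chain carbon would also stay within the scatter of compound 4.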